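The source may report more compounds than this note shows. Statements on the series, on what has been measured and on what is new or still open speak of the compounds shown alone.

Compound 1 `COc1cc(-c2nn(-c3cccc(NC(=O)Nc4ccc(Cl)c(C(F)(F)F)c4)c3)cc2-c2ccncc2)ccc1Cl` gives 1140 nM in a functional assay on NCI-H522 cells (Homo sapiens) for inhibition, read by sulforhodamine B assay, with a stated time of 48 h; a lower number here means a stronger inhibitor of growth, a higher number a weaker inhibitor of growth.
Compound 2 `COc1cc(-c2nn(-c3cccc(NC(=O)c4ccccc4)c3)cc2-c2ccncc2)ccc1Cl` gives 317 nM in this assay.

Among these two numbers compound 1 stands highest; its nearest neighbour is compound 2, reached by a 3.6-fold lower number from compound 1 to compound 2 (0.56 log units; beyond the scatter) through exchange of the group on the carbonyl carbon. Compound 3 `O=C(Nc1cccc(-n2cc(-c3ccncc3)c(-c3ccc(Cl)c(O)c3)n2)c1)Nc1ccc(Cl)c(C(F)(F)F)c1` has not yet been measured in this assay. It differs from compound 1 at another place: hydrogen in place of methyl on an oxygen on an aromatic ring. Among the measured compounds shown here, no measured step touches this oxygen; the single step known, from compound 1 to compound 2, changes the amide end of the molecule and so does not speak to this exchange. With nothing in the data to argue for a shift in either direction, the expectation for compound 3 is a number close to that of compound 1, with the step of a 1.0-fold lower number from compound 1 to compound 3 (0.02 log units; within the scatter) expected to stay within the scatter. The estimate for compound 3 in this assay is therefore 1100 nM, with a range from 400 nM to 3200 nM.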

Compound 3, concentration for 50% growth inhibition: 720 nM
Estimate against measurement, compound 3: 1.5-fold (0.18 log units) above; the range from low to high includes it.
By their numbers in this assay, from the lowest: compound 2; then compounds 3 and 1 (each within the scatter of the next).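

In this assay, among the compounds shown here, hydrogen in place of methyl on the oxygen, which turns methoxy into hydroxy, gives a 1.6-fold lower number from compound 1 to compound 3 (0.20 log units; within the scatter), the first reading of any change at this position. The step does not separate the two compounds, so with the (4-chloro-3-(trifluoromethyl)phenyl)amino group on the carbonyl carbon, the methyl on this oxygen can be given up without a difference that stands out from the scatter. No measurement shown here offers an explanation for this result.

As far as these compounds go, it remains open whether the same exchange would also stay within the scatter with phenyl on the carbonyl carbon, as in compound 2. Also open, from the compounds shown here alone, is whether a longer chain on this oxygen, such as ethyl or propyl, or an amine in place of the hydroxy, would give a step beyond the scatter.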